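Swapping an ester for a benzyl ether on a shared core

The source may hold more compounds than are shown below. What is called first, only, known or untested is meant among the compounds shown, and "the series" means these compounds.

Of the compounds shown here, three have been measured in a functional assay on HEK293 cells for agonist activity at G-protein coupled receptor 39 (Homo sapiens), read by scintillation proximity assay and inositol phosphate accumulation, with a stated time of 75 min, in the presence of a further agent that is not named here; a higher number here means that more compound is needed for the effect, a lower number that less compound is needed. Compound 1, `CCC(C(=O)NC1CC(=O)Nc2c1c(C)nn2-c1ncnc2nc[nH]c12)c1ccccc1`, gives 5 nM in this assay. Compound 2, `O=C1/C(=C/NCCCO)C(c2ccccc2)=NN1c1nc2ccccc2s1`, gives 200 nM. Compound 3, `Cc1nn(-c2ncnc3nc[nH]c23)c2c1C(OC(=O)c1ccc(F)cc1)CC(=O)N2`, gives 4 nM, the lowest of the three numbers; compound 1 lies nearest to it, within the usual scatter of repeated measurements, so no order can be read between these two, while compound 2 lies furthest away, beyond the scatter.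

The next compound, compound 4, `Cc1nn(-c2ncnc3nc[nH]c23)c2c1C(OCc1ccccc1C#N)CC(=O)N2`, keeps the core of compound 3 and changes one group:

2-cyanobenzyl in place of (4-fluorophenyl)carbonyl on an oxygen on a saturated carbon

Among the compounds with values here, no pair of measured compounds differing in one place is available, so the size of this step can only be estimated. Since compound 1, with an amide in place of the oxygen-linked group, and compound 3 sit close together, the core appears to tolerate different groups at this position, and a moderate rise in the number, at or a little beyond the scatter, is expected for this assay. The step from compound 3 to compound 4 is estimated to be a 3.8-fold higher number from compound 3 to compound 4 (0.57 log units; beyond the scatter). Compound 4 is expected to give about 15 nM in this assay, with a range from 4 nM to 60 nM.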

Compound 4, half-maximal effective concentration: 8 nM
For compound 4 the middle estimate is 1.9-fold (0.27 log units) above the measured one; the range from low to high includes it.
By their numbers in this assay, from the lowest: compounds 3, 1 and 4 (each within the scatter of the next); then compound 2.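

In this assay the change gives a 2.0-fold higher number from compound 3 to compound 4 (0.30 log units; within the scatter) and so the (4-fluorophenyl)carbonyl and the 2-cyanobenzyl group cannot be told apart on this oxygen on a saturated carbon. Within the data shown here, this is the first direct comparison at this position, and it shows that the carbonyl of the ester in compound 3 can give way to the benzyl ether of compound 4 with no change that can be read in this measurement, although the fluorine also leaves and a nitrile enters in the same step. Nothing measured here explains this outcome.

Among these compounds, the single step therefore cannot separate the parts of the change, and it remains open whether a plain benzyl group, with neither fluorine nor nitrile, would give a number in the same range on this oxygen. From the compounds shown here alone, it is equally open how far this tolerance extends to groups of a different kind at this place, such as a small methyl group, a longer alkyl chain, or a chain ending in an amine or a carboxylic acid.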